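This account rests on a few compounds, and the source may have more. Where it says the series, first, only, none or still open, it means among the compounds named here.

In a physicochemical assay for solubility (on this read-out lower numbers stand for lower solubility and higher numbers for higher solubility), compound 1 `CCCCCCCCCCCCCCCC(=O)n1c(=S)oc2ccccc21` gives 63000 nM as its reading, compound 2 `CCCCCCCCCC(=O)n1c(=S)oc2ccccc21` gives 100000 nM and compound 3 `O=C(/C=C/c1ccccc1)n1c(=S)oc2ccccc21` gives 80000 nM on the same scale. Compound 2 therefore stands among three numbers that lie within the usual scatter of one another. Compound 4 `O=C(CCCc1ccccc1)n1c(=S)oc2ccccc21` differs from compound 2 by one change (phenyl in place of hexyl on a saturated chain carbon, three bonds along the chain from a carbonyl carbon): phenyl in place of hexyl on a saturated chain carbon, three bonds along the chain from a carbonyl carbon. Within the data shown here, the one measured step that bears on it is a 1.6-fold higher number from compound 1 to compound 2 (0.20 log units; within the scatter) and that step stayed within the scatter, while no measured step puts phenyl in place of hexyl. Hence no step beyond the scatter is expected in this assay for this change. The estimated step (a 1.3-fold lower number from compound 2 to compound 4 (0.10 log units; within the scatter)) is expected to stay within the scatter. Compound 4 is estimated at 80000 nM with an expected range from 40000 nM to 130000 nM as its upper end.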

Compound 4, solubility: 100000 nM
For compound 4 the middle estimate is 1.3-fold (0.10 log units) below the measured one, and the stated range covers the measured number.
By their numbers in this assay, from the lowest: compounds 1, 3, 2 and 4 (each within the scatter of the next).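

In this assay, phenyl in place of hexyl on a saturated chain carbon, three bonds along the chain from a carbonyl carbon, gives no change at the digits printed from compound 2 to compound 4 (within the scatter). Among these compounds, this is the first measured step at this place to put a six-membered aromatic ring where an open chain stood, and the reading stays within the scatter. Nothing available explains this result.

From the compounds shown here alone, it remains open whether an amine or a carboxylic acid at this place would also stay within the scatter, and whether a longer chain ending in phenyl would do the same.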